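Straightening the amine-bearing chain of compound 3

The source may report more compounds than this note shows. Statements on the series, on what has been measured and on what is new or still open speak of the compounds shown alone.

Compound 3 `CC(C)(C)[C@H](N)CN(C(=O)[C@@H]1C[C@H]1c1ccccc1)c1ccc(-c2ccccc2)cc1` has been measured in a functional assay for agonist activity at G protein-coupled receptor 88 (Homo sapiens), read by HTRF and cAMP accumulation (on this read-out lower numbers stand for an effect already at smaller amounts and higher numbers for an effect only at larger amounts of compound), where compound 3 gives 11 nM. Among the compounds with a single number it stands highest; its nearest neighbour is compound 2 `CC[C@@H](C)[C@H](N)CN(C(=O)[C@@H]1C[C@H]1c1ccccc1)c1ccc(-c2ccccc2)cc1`, which in this assay gives 1.4 nM, a step of a 7.9-fold higher number from compound 2 to compound 3 (0.90 log units; beyond the scatter). Compound 1 `CC[C@H](C)[C@H](N)CN(C(=O)[C@@H]1C[C@H]1c1ccccc1)c1ccc(-c2ccccc2)cc1` has two entries in this assay, and compound 1 gives 230 nM; 800 nM (2 entries). Compound 1 and compound 2 differ only in the fact that compounds 1 and 2 differ only in the configuration as drawn, and the several entries of compound 1 in this assay, 230 nM; 800 nM (2 entries) shows their numbers lie far apart from those of compound 2. Compound 4 `CC(C)CCNCCN(C(=O)[C@@H]1C[C@H]1c1ccccc1)c1ccc(-c2ccccc2)cc1` has not yet been measured. It differs from compound 3 by (isopentylamino)methyl in place of 1-amino-2,2-dimethylpropyl on a saturated chain carbon bound to an amide-type nitrogen, and with this change the defined stereocentre is gone. Going by the values given here, no measured step covers this change directly; the one change made at this part of compound 3 so far already moved the number beyond the scatter, and the gap between compound 1 and compound 2 shows how sensitive this assay is to the arrangement at that chain carbon. A higher number is therefore expected for compound 4, roughly an 18-fold higher number from compound 3 to compound 4 (1.26 log units; beyond the scatter). Compound 4 is estimated at 200 nM, within a range from 30 nM to 2000 nM.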

Compound 4, half-maximal effective concentration: 5.1 nM
For compound 4 the middle estimate is 39-fold (1.59 log units) above the measured one; the measured number lies below the stated range.
By their numbers in this assay, from the lowest: compound 2; then compound 4; then compound 3.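

The earlier pair tied the number to the arrangement at this chain carbon: the fact that compounds 1 and 2 differ only in the configuration as drawn. Compound 4 has no defined stereocentre in this part of the molecule, yet in this assay (isopentylamino)methyl in place of 1-amino-2,2-dimethylpropyl gives a 2.2-fold lower number from compound 3 to compound 4 (0.33 log units; beyond the scatter), so among these compounds a low number does not depend on that stereocentre. The open chain still does not match the branched compound 2, with a 3.6-fold higher number from compound 2 to compound 4 (0.56 log units; beyond the scatter).

From the compounds shown here alone, the loss of the stereocentre and the move of the chain onto the amine nitrogen arrive together in compound 4, so their separate shares remain open. Also open, going by these compounds, is whether a shorter butyl chain or a cyclohexylmethyl group on that nitrogen would give a number closer to that of compound 2.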